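Charged amine groups on a bradykinin receptor antagonist series

The source may hold more compounds than are shown below. What is called first, only, known or untested is meant among the compounds shown, and "the series" means these compounds.

Compound 1 `Cc1cc(C)c2cccc(OCc3c(Cl)ccc(S(=O)(=O)NC4(C(=O)N5CCN(C(=O)[C@@H](N)CCCC[N+](C)(C)C)CC5)CCCC4)c3Cl)c2n1` gives a limit of the assay, < 10000 nM.
Compound 2 `Cc1cc(C)c2cccc(OCc3c(Cl)ccc(S(=O)(=O)NC4(C(=O)N5CCN(C(=O)[C@H](CCCC[N+](C)(C)C)[N+](C)(C)C)CC5)CCCC4)c3Cl)c2n1` gives a limit of the assay, < 10000 nM.
Compound 3 `Cc1cc(C)c2cccc(OCc3c(Cl)ccc(S(=O)(=O)NC4(C(=O)N5CCN(C(=O)C[C@@H](N)CCCN)CC5)CCCC4)c3Cl)c2n1` gives a limit of the assay, < 10000 nM.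

In an assay on isolated protein for binding affinity to B1 bradykinin receptor (Homo sapiens) (a higher number here means a weaker inhibitor, a lower number a stronger inhibitor), none of the three measured values is a number. Compound 2 differs from compound 1 by a group of 4 heavy atoms (3 carbon, 1 nitrogen; no ring) in place of one nitrogen atom, on a saturated chain carbon bound to a carbonyl carbon and a saturated chain carbon, and a step that the two limits leave unreadable from compound 1 to compound 2. The two cores differ as a group of 7 heavy atoms (5 carbon, 2 nitrogen; no ring) in place of a group of 10 heavy atoms (8 carbon, 2 nitrogen; no ring), on a carbonyl carbon, and a step that the two limits leave unreadable from compound 1 to compound 3. Compound 4 `Cc1cc(C)c2cccc(OCc3c(Cl)ccc(S(=O)(=O)NC4(C(=O)N5CCN(C(=O)C[C@@H](N)CCC[N+](C)(C)C)CC5)CCCC4)c3Cl)c2n1` is not yet measured; it differs from compound 3 by a group of 4 heavy atoms (3 carbon, 1 nitrogen; no ring) in place of one nitrogen atom, on a saturated chain carbon, four bonds along the chain from an amine nitrogen, the same kind of change as from compound 1 to compound 2, though there the place was on a saturated chain carbon bound to a carbonyl carbon and a saturated chain carbon, while here it is on a saturated chain carbon, four bonds along the chain from an amine nitrogen. Because the limit of < 10000 nM in this assay, at which 3 of the 3 values shown sit, holds for every measured compound, no size can be read for this change, so the step from compound 3 to compound 4 is expected to be a step that the limit leaves unreadable from compound 3 to compound 4. Compound 4 is expected to give 5000 nM, between 1000 nM and 10000 nM, most likely again only as a limit.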

Compound 4, inhibition constant: < 10000 nM
Compound 4 was reported as a limit; the forecaster's own chance of this, stated with the estimate: 80%; the middle value does not contradict the limit.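

No step can be read from compound 3 to compound 4 or from compound 1 to compound 4, since each gives only a limit and not a number: the limit of < 10000 nM in this assay, at which 4 of the 4 values shown sit.

In this assay, as far as these compounds go, the actual strength of compound 1, compound 2, compound 3 and compound 4 stays open, and so does the size of any change between them.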